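The source may report more compounds than this note shows. Statements on the series, on what has been measured and on what is new or still open speak of the compounds shown alone.

Two pyrazoline-type compounds have been measured here, and a third awaits its number. Compound 1 `Cc1cc(O)c(C2=NN(c3ccc(S(N)(=O)=O)cc3)C(c3ccccc3O)C2)cc1Cl` has the higher of the two measured numbers: in a functional assay on the whole organism (strain Wistar) for inhibition, with Rattus norvegicus as the target, read by paw edema, with stated times of 30 min and 3 h, at a dose of 20 mg/kg by the oral route (on this read-out higher numbers stand for more inhibition at the one dose given (going by the name of the read-out) and lower numbers for less inhibition), compound 1 gives 73.6%. Compound 2 `COc1cc(C)c(Cl)cc1C1=NN(c2ccc(S(N)(=O)=O)cc2)C(c2cccc(O)c2)C1` stands lowest of the two numbers seen so far, and in this assay compound 2 gives 39.5%, a gap to compound 1 that lies beyond the usual scatter of repeated measurements.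

Compound 3 `COc1cc(C)c(Cl)cc1C1=NN(c2ccc(S(N)(=O)=O)cc2)C(c2ccc(OC)c(OC)c2OC)C1` has not yet been tested. It is built on the shared core of compound 2 and differs from it in one place: 2,3,4-trimethoxyphenyl in place of 3-hydroxyphenyl on a saturated ring carbon. Within the data shown here, no pair of measured compounds differing in one place is available, so nothing measured tells how large a change of this kind should be. For that reason the step from compound 2 to compound 3 in this assay is expected to be modest, a number 5.5 percentage points higher from compound 2 to compound 3 (within the scatter), and may well fall inside the scatter. On that basis compound 3 is estimated to reach 45% in this assay, with a plausible range from 22% to 68%.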

Compound 3, a percentage reported as inhibition, in the whole organism at one dose (the size of the read-out at that dose, not a potency): 34.2%
Beside the measured number, compound 3's estimate is 10.8 percentage points above it, within the range that was stated.
By their numbers in this assay, from the lowest: compounds 3 and 2 (each within the scatter of the next); then compound 1.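

Among these compounds, on a saturated ring carbon next to the ring nitrogen, 2,3,4-trimethoxyphenyl in place of 3-hydroxyphenyl is the one change at a single place that can be read in this assay, and it comes out as a number 5.3 percentage points lower from compound 2 to compound 3 (within the scatter). In this single pair, the group that enters has 12 heavy atoms and 0 hydrogen-bond donors, the group that leaves has 7 heavy atoms and 1 hydrogen-bond donor, and even so the read-out does not separate the two compounds at the one dose given. Nothing measured here offers an explanation for this result.

On these data alone, the swap replaces the whole substituted phenyl group in one move, so what the hydroxyl group and each of the three methoxy groups contribute on its own remains open. Also open, as far as these compounds go, is how this carbon would respond to a group of a different kind, such as an unsubstituted phenyl, a phenyl carrying an amine or a carboxylic acid, or a longer alkyl chain in place of the aromatic ring.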